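This account rests on a few compounds, and the source may have more. Where it says the series, first, only, none or still open, it means among the compounds named here.

Measured in a functional assay on A549 cells (Homo sapiens) for cytotoxicity, read by MTT assay, with a stated time of 48 h; a lower number here means a stronger inhibitor, a higher number a weaker inhibitor:

Compound 1 `CC(C)=CCC/C(C)=C/CC/C(C)=C/CC[C@@H]1[C@@]2(C)CC/C(=N\OCc3cn(-c4cccc(C(F)(F)F)c4)nn3)C(C)(C)[C@@H]2CC[C@@]1(C)O`: 12900 nM
Compound 2 `COc1cccc(-n2cc(COc3ccc(/C=C4\C[C@]5(C)[C@@H](CC/C=C(\C)CC/C=C(\C)CCC=C(C)C)[C@](C)(O)CC[C@H]5C(C)(C)C4=O)cc3)nn2)c1`: 45700 nM

Going by the values given here, of the two compounds measured so far, compound 2 gives the highest number in this assay, a value 45700 nM that lies above that of compound 1, a gap beyond the usual scatter. Among the compounds with values here, both compounds carry the same lipid-bearing core, and differ in the linker and in the aryl group on the triazole, so no single-change step between measured compounds is available.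

Compound 3 `CC(C)=CCC/C(C)=C/CC/C(C)=C/CC[C@@H]1[C@@]2(C)C/C(=C\c3ccc(OCc4cn(-c5ccncc5)nn4)cc3)C(=O)C(C)(C)[C@@H]2CC[C@@]1(C)O` keeps the framework of compound 2 and changes only the group on the triazole nitrogen: pyridin-4-yl in place of 3-methoxyphenyl on an aromatic nitrogen. Nothing in the measured pair shows how this aryl exchange alone affects the read-out, so the expectation for compound 3 rests on compound 2 and its value 45700 nM with wide uncertainty. A step from compound 2 to compound 3 of no more than the scatter, in either direction, is expected, a 1.3-fold lower number from compound 2 to compound 3 (0.12 log units; within the scatter). Compound 3 is therefore estimated at 35000 nM in this assay, with a range from 12000 nM to 100000 nM.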

Compound 3, half-maximal inhibitory concentration: 34000 nM
Compound 3: the middle estimate sits 1.0-fold (0.01 log units) above what was measured, and the stated range covers the measured number.
By their numbers in this assay, from the lowest: compound 1; then compounds 3 and 2 (each within the scatter of the next).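

In this assay, placing pyridin-4-yl in place of 3-methoxyphenyl on the aromatic nitrogen of the five-membered aromatic ring with 3 nitrogen gives a 1.3-fold lower number from compound 2 to compound 3 (0.13 log units; within the scatter) and so provides the first single-change step among these compounds. At this position, a six-membered aromatic ring with 1 hetero atom and 6 heavy atoms therefore reads within the scatter of a carbon-only ring bearing methoxy with 8 heavy atoms, so this exchange does not separate the two compounds in the read-out. No measured information on any property of these groups is available to account for this result.

The compounds shown leave open whether a different group on this nitrogen, such as pyridin-3-yl, a benzoic acid or an aminoethyl chain, would move the number beyond the scatter. Going by these compounds alone, they also leave the separate contributions of the linker and of the aryl group unresolved, as compound 1 differs from both other compounds in more than one place and offers no single-change step.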